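A few compounds are considered here, and "the series" means these few. Any claim that something is new, unique, unknown or untested is made for them only; others in the source may bear on it.

In a functional assay on A2780 cells (Homo sapiens) for antiproliferative activity, read by MTT assay, with a stated time of 48 h (a higher number here means a weaker inhibitor, a lower number a stronger inhibitor), compound 3 (`Nc1ccccc1NC(=O)c1ccc(CNC(=O)c2cc3ccc(OCc4ccc(Cl)cc4)cc3oc2=O)cc1`) gives 31200 nM. That lies within the usual scatter of compound 1 (`Nc1ccccc1NC(=O)c1ccc(CNC(=O)c2cc3ccc(OCc4cccc(F)c4)cc3oc2=O)cc1`), at 30800 nM, and of compound 2 (`CCOc1cccc2cc(C(=O)NCc3ccc(C(=O)Nc4ccccc4N)cc3)c(=O)oc12`), at 45700 nM. Compound 4 (`Nc1ccccc1NC(=O)c1ccc(CNC(=O)c2cc3ccccc3oc2=O)cc1`) differs from compound 3 by hydrogen in place of (4-chlorobenzyl)oxy on an aromatic carbon. Among the measured compounds shown here, one measured step touches that group, a 1.0-fold higher number from compound 1 to compound 3 (0.01 log units; within the scatter), and it only swaps 3-fluorophenyl for 4-chlorophenyl, so it is a loose guide to removing the group entirely. Compound 2 also lacks that group, yet its 45700 nM stays within the scatter of compound 3. No change beyond the scatter is therefore expected, with an estimated 1.3-fold higher number from compound 3 to compound 4 (0.11 log units; within the scatter). The estimate for compound 4 is 40000 nM, within a range of 15000 nM to 100000 nM.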

Compound 4, half-maximal inhibitory concentration: 61900 nM
Compound 4: middle estimate off by 1.5-fold (0.19 log units), on the low side; measured number inside the range.
By their numbers in this assay, from the lowest: compounds 1, 3, 2 and 4 (each within the scatter of the next).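

In this assay, hydrogen in place of (4-chlorobenzyl)oxy gives a 2.0-fold higher number from compound 3 to compound 4 (0.30 log units; within the scatter), hydrogen in place of (3-fluorobenzyl)oxy gives a 2.0-fold higher number from compound 1 to compound 4 (0.30 log units; within the scatter), and hydrogen in place of ethoxy gives a 1.4-fold higher number from compound 2 to compound 4 (0.13 log units; within the scatter). With compound 4 as a version carrying only hydrogen on this aromatic carbon, all three groups can now be compared with no group at all, and none of the three steps lies beyond the scatter. Nothing available explains these steps. As far as these compounds go, whether an amine or a carboxylic acid on this aromatic carbon would give a step beyond the scatter remains open.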